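A few compounds are considered here, and "the series" means these few. Any claim that something is new, unique, unknown or untested is made for them only; others in the source may bear on it.

Measured compounds:
compound 1 `CCN(c1nc(Cl)nc(N[C@H](C)c2ccccc2)n1)C(C)C`, 52500 nM;
compound 2 `CCCCNc1nc(Cl)nc(N[C@H](C)c2ccccc2)n1`, 38900 nM;
compound 3 `CCCCNc1nc(Cl)nc(N[C@@H](C)c2ccccc2)n1`, 12900 nM.

In an ADME assay on the whole organism for inhibition, with Echinochloa crus-galli var. formosensis as the target, with a stated time of 4 days (a higher number here means a weaker inhibitor, a lower number a stronger inhibitor), compound 3 gives the lowest of the three numbers. Compound 2 and compound 3 share every atom and bond; their difference is the two compounds have the same atoms and bonds and differ only in configuration as drawn: 1 of 1 stereo elements differ; a stereocentre at a saturated chain carbon is drawn R in compound 2 and S in compound 3, and the step of a 3.0-fold lower number from compound 2 to compound 3 (0.48 log units; beyond the scatter) rests on nothing more than the fact that compounds 2 and 3 differ only in the configuration as drawn. The second change in this set is ethyl(isopropyl)amino in place of butylamino on an aromatic carbon, which made the step of a 1.3-fold higher number from compound 2 to compound 1 (0.13 log units; within the scatter). The same change, at the same place, carries compound 3 to compound 4 `CCN(c1nc(Cl)nc(N[C@@H](C)c2ccccc2)n1)C(C)C`, whose difference from compound 3 is ethyl(isopropyl)amino in place of butylamino on an aromatic carbon. Because the earlier step of a 1.3-fold higher number from compound 2 to compound 1 (0.13 log units; within the scatter) stayed within the scatter, the step from compound 3 to compound 4 is expected to be small as well, about a 1.3-fold higher number from compound 3 to compound 4 (0.12 log units; within the scatter). Compound 4 is therefore estimated at 17000 nM in this assay, between 7000 nM and 42000 nM.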

Compound 4, half-maximal inhibitory concentration: 229 nM
For compound 4 the middle estimate is 74-fold (1.87 log units) above the measured one, outside the stated range (below it).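

In this assay the exchange of butylamino for ethyl(isopropyl)amino gave a 56-fold lower number from compound 3 to compound 4 (1.75 log units; beyond the scatter), so the change did not carry over unchanged from one core to the other: the same change on two cores in this assay, a 1.3-fold higher number (0.13 log units; within the scatter) from compound 2 to compound 1 and a 56-fold lower number (1.75 log units; beyond the scatter) from compound 3 to compound 4, 76-fold (1.88 log units) apart, beyond the scatter of two such steps. With ethyl(isopropyl)amino in both compounds, configuration alone gave a 230-fold lower number from compound 1 to compound 4 (2.36 log units; beyond the scatter): the fact that compounds 1 and 4 differ only in the configuration as drawn. Among these four compounds, the result of the change therefore depends on the configuration drawn at the stereocentre, but the data do not show why, and two pairs give no general rule for other amino groups.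

The compounds shown leave open whether the large step on the core of compound 3 needs both the ethyl and the isopropyl parts. Isopropylamino or diethylamino at that position would address this question.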